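The compounds below may be only part of what the source reports. "The series", "measured", "known", "first", "only" and "open" are said of these compounds alone.

Measured compounds:
- compound 1 `COc1ccccc1NC(=O)N[C@@H](C)c1ccccc1`, which in an ADME assay on the whole organism with Oryza sativa as the target, tested at 10 uM (on this read-out lower numbers stand for a stronger effect and higher numbers for a weaker effect at the one concentration tested), gives 95%
- compound 2 `C[C@H](NC(=O)Nc1ccccc1F)c1ccccc1`, which in this assay gives 65%
- compound 3 `C[C@H](NC(=O)Nc1ccccc1I)c1ccccc1`, which in this assay gives 98%

Compound 2 stands lowest of the three numbers; the step of a number 30 percentage points lower from compound 1 to compound 2 (beyond the scatter) and the step of a number 33 percentage points higher from compound 2 to compound 3 (beyond the scatter) both lie beyond the scatter. Compound 4 `Cc1ccc(NC(=O)N[C@@H](C)c2ccccc2)c(F)c1` differs from compound 2 by methyl in place of hydrogen on an aromatic carbon. Going by the values given here, no measured step exchanges hydrogen for methyl; the two known steps concern only the fluoro group, which compound 4 keeps. The expected step of a number 5 percentage points higher from compound 2 to compound 4 (within the scatter) is therefore small, within the scatter, with wide uncertainty. Compound 4 is estimated at 70%, ranging from 50% to 95%.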

Compound 4, a percentage reported as activity, at one concentration (the size of the read-out at that concentration, not a potency): 100%
Beside the measured number, compound 4's estimate is 30 percentage points below it; measured number above the stated range.
By their numbers in this assay, from the lowest: compound 2; then compounds 1, 3 and 4 (each within the scatter of the next).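

In this assay, methyl in place of hydrogen on an aromatic carbon, meta to a fluoro group and para to a large group, gives a number 35 percentage points higher from compound 2 to compound 4 (beyond the scatter) and so shows that keeping the fluoro group does not by itself keep the low number of compound 2. The earlier steps shown here exchanged only the group that fluoro occupies, whereas this step shows that a single added carbon at a second place can also move the read-out. Nothing available explains this step. Still open, as far as these compounds go, is whether an amine or an ethyl chain at this place would act as methyl does, and whether methyl here would have the same effect with another group in place of fluoro.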